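Amino for carboxy at the chain end of the shared core

The compounds below may be only part of what the source reports. "The series", "measured", "known", "first", "only" and "open" are said of these compounds alone.

Measured compounds:
compound 1 `O=C(CCCCCCc1cccnc1)c1ncc(-c2ccccn2)o1` — 32 nM
compound 2 `O=C(O)c1ccc(CCCCCCC(=O)c2ncc(-c3ccccn3)o2)cc1` — > 600 nM

In an assay for inhibition of Fatty-acid amide hydrolase 1 (Rattus norvegicus) (a higher number here means a weaker inhibitor, a lower number a stronger inhibitor), compound 1 gives 32 nM. For compound 2 the reported > 600 nM is a limit of the assay and not a number. Compound 2 thus sits at the limit of > 600 nM in this assay, at which 1 of the 2 values shown sits, so only an upper bound on its potency is known. Among the compounds with values here, the single measured step, an at least 18-fold higher number from compound 1 to compound 2 (1.27 log units; beyond the scatter), is large and beyond the scatter. Compound 3 `Nc1ccc(CCCCCCC(=O)c2ncc(-c3ccccn3)o2)cc1` carries amino in place of carboxy on an aromatic carbon. Within the data shown here, no measured step covers this particular exchange; the one step that exists replaces a different end group and bears on it only indirectly, showing that the carboxyphenyl end gives the weaker of the two measured compounds. Removing the carboxy while keeping the phenyl is expected to recover part of that loss, giving an expected step of an at least 3.0-fold lower number from compound 2 to compound 3 (0.47 log units; beyond the scatter). Compound 3 is estimated at 200 nM, within 40 nM to 1000 nM.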

Compound 3, inhibition constant: 3 nM
The estimate for compound 3 lay 67-fold (1.82 log units) above the measured number, and the stated range ends above it.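

In this assay, the phenyl end of the chain does not by itself carry the loss seen with compound 2, since amino in place of carboxy on the same aromatic carbon gives an at least 200-fold lower number from compound 2 to compound 3 (2.30 log units; beyond the scatter). Compound 2 stands at a limit and not at a number, so this step has a bound only: the limit of > 600 nM in this assay, at which 1 of the 3 values shown sits. The 4-aminophenyl end also exceeds the pyridin-3-yl end, with an 11-fold lower number from compound 1 to compound 3 (1.03 log units; beyond the scatter), which makes compound 3 the strongest of the three compounds in this assay.

The compounds shown do not separate a gain from the amine itself from the mere loss of the carboxylic acid; a plain phenyl end would be needed to tell these apart. Going by these compounds, how the 4-aminophenyl end behaves on a shorter or longer chain also remains open.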